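The source may report more compounds than this note shows. Statements on the series, on what has been measured and on what is new or still open speak of the compounds shown alone.

Measured so far in an assay on THP-1 cells for antagonist activity at P2X purinoceptor 7 (Homo sapiens), read by ELISA, with a stated time of 30 min; a higher number here means a weaker inhibitor, a lower number a stronger inhibitor:
compound 1 `CN(C)c1ccc(C(=O)N2CCC(n3cncc3-c3ccc(OS(=O)(=O)c4cccc5cnccc45)cc3)CC2)cc1`: 2.19 nM
compound 2 `CN(C)c1ccc(C(=O)N2CCC(n3cncc3-c3ccc(OS(=O)(=O)c4cccc(C#N)c4)cc3)CC2)cc1`: 10 nM
compound 3 `CNC(=O)c1cccc(S(=O)(=O)Oc2ccc(-c3cncn3C3CCN(C(=O)c4ccc(N(C)C)cc4)CC3)cc2)c1`: 22 nM

Compound 3 gives the highest number of the three in this assay: a 10-fold higher number from compound 1 to compound 3 (1.00 log units; beyond the scatter) and a 2.2-fold higher number from compound 2 to compound 3 (0.34 log units; beyond the scatter). Compound 4 `CN(C)c1ccc(C(=O)N2CCC(n3cncc3-c3ccc(OS(=O)(=O)c4cccc(C(=O)NC5CC5)c4)cc3)CC2)cc1` differs from compound 3 by cyclopropyl in place of methyl on an amide-type nitrogen. For the measured compounds named here, none of the measured steps touches this amide nitrogen: a 4.6-fold higher number from compound 1 to compound 2 (0.66 log units; beyond the scatter) and a 10-fold higher number from compound 1 to compound 3 (1.00 log units; beyond the scatter) swap the whole group on the sulfonyl sulfur, and a 2.2-fold higher number from compound 2 to compound 3 (0.34 log units; beyond the scatter) replaces cyano with methylcarbamoyl on an aromatic carbon, so they give no direct guide. Lacking any precedent for this change, the step from compound 3 to compound 4 in this assay is expected to be small, a 1.1-fold lower number from compound 3 to compound 4 (0.04 log units; within the scatter), with no firm direction. Compound 4 is therefore estimated at 20 nM, within 7 nM to 60 nM.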

Compound 4, half-maximal inhibitory concentration: 1.03 nM
Compound 4: middle estimate off by 19-fold (1.29 log units), on the high side; the measured number lies below the stated range.
By their numbers in this assay, from the lowest: compound 4; then compound 1; then compound 2; then compound 3.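

Changing the group on this amide nitrogen from methyl to cyclopropyl has a large effect in this assay (a 21-fold lower number from compound 3 to compound 4 (1.33 log units; beyond the scatter)), the biggest step yet seen in the series. The 3-(cyclopropylcarbamoyl)phenyl group now gives a lower number than a lone cyano on the aromatic carbon (a 9.7-fold lower number from compound 2 to compound 4 (0.99 log units; beyond the scatter)), and also a lower number than isoquinolin-5-yl on the sulfonyl sulfur (a 2.1-fold lower number from compound 1 to compound 4 (0.33 log units; beyond the scatter)). Nothing available explains why. The compounds shown leave open whether this gain is particular to the three-membered ring, or whether ethyl, isopropyl or cyclobutyl on this nitrogen would behave alike.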